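Anilino Replaces Amino on the Shared Core

This account rests on a few compounds, and the source may have more. Where it says the series, first, only, none or still open, it means among the compounds named here.

The series rests on one core carrying a benzoyl group, a 4-bromophenyl group and an imidazolylpropyl chain, and differs at a single position. Compound 1 `CC(C)OC1=C(C(=O)c2ccccc2)C(c2ccc(Br)cc2)N(CCCn2ccnc2)C1=O` bears an isopropoxy group there and in a functional assay on A549 cells (Homo sapiens) for antiproliferative activity, read by MTT assay, with a stated time of 72 h (a higher number here means a weaker inhibitor, a lower number a stronger inhibitor), compound 1 gives 8720 nM. Compound 2 `CCCCOC1=C(C(=O)c2ccccc2)C(c2ccc(Br)cc2)N(CCCn2ccnc2)C1=O` carries a butoxy group instead, and in this assay compound 2 gives 18500 nM; the step of a 2.1-fold higher number from compound 1 to compound 2 (0.33 log units; beyond the scatter) is the only one that can be put into numbers here. On these data alone, compound 3 `NC1=C(C(=O)c2ccccc2)C(c2ccc(Br)cc2)N(CCCn2ccnc2)C1=O` replaces the ether oxygen by an amino group, and in this assay compound 3 is reported as "not active" (no number reported), with no number attached, so its standing on the scale is unknown beyond the fact that it fell short of measurable inhibition. Compound 4 `O=C(C1=C(Nc2ccc(Cl)cc2)C(=O)N(CCCn2ccnc2)C1c1ccc(Br)cc1)c1ccccc1` differs from compound 3 by 4-chlorophenyl in place of hydrogen on an amine nitrogen. Going by the values given here, no measured step touches this position in this way; the step from compound 1 to compound 2 concerns an ether and offers no guide. Because compound 3 gave only "not active" (no number reported), no direction can be derived from the data. As a rough expectation, compound 4 is estimated at 15000 nM, with a range from 3000 nM to 80000 nM.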

Compound 4, half-maximal inhibitory concentration: 30000 nM
Compound 4: middle estimate off by 2.0-fold (0.30 log units), on the low side; low and high end bracket the measured number.
By their numbers in this assay, from the lowest: compound 1; then compounds 2 and 4 (each within the scatter of the next).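

Compound 4 shows that this position can carry a substituted amine and still give a number 30000 nM in this assay, whereas compound 3, with the free amino group, was reported only as "not active"; the step from compound 3 to compound 4 therefore cannot be read as a size. Set against the ethers on the same double-bonded ring carbon, (4-chlorophenyl)amino shows no separation from butoxy (a 1.6-fold higher number from compound 2 to compound 4 (0.21 log units; within the scatter)), but it does not match isopropoxy (a 3.4-fold higher number from compound 1 to compound 4 (0.54 log units; beyond the scatter)), so among the three groups with numbers, only isopropoxy stands apart. Nothing available here accounts for these differences.

The compounds shown leave open what a plain phenyl, a 4-methoxyphenyl or a butyl group on the same amine nitrogen would give, and so whether the ring, the chlorine or simply the replacement of the amine hydrogen separates compound 4 from compound 3. They also leave open how a methoxy or a cyclopentyloxy group at this position would compare with the isopropoxy group of compound 1.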